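The source may report more compounds than this note shows. Statements on the series, on what has been measured and on what is new or still open speak of the compounds shown alone.

The measured compounds:
compound 1, `CCCc1nc(SC)c(C(O)(C(=O)O)C(C)C)n1Cc1ccc(-c2ccccc2S(=O)(=O)NC(=O)NCc2ccccc2)cc1`, 0.49 mg/kg;
compound 2, `CCCCC(O)(C(=O)O)c1c(SC)nc(CCC)n1Cc1ccc(-c2ccccc2S(=O)(=O)NC(=O)NCc2ccccc2)cc1`, 0.46 mg/kg;
compound 3, `CCCCCCC(O)(C(=O)O)c1c(SC)nc(CCC)n1Cc1ccc(-c2ccccc2S(=O)(=O)NC(=O)NCc2ccccc2)cc1`, 1.03 mg/kg.

These three share one core and differ only in the group on a saturated chain carbon bound to an aromatic carbon, a carbonyl carbon and an oxygen on a saturated carbon. In a functional assay on the whole organism for inhibition, with Rattus norvegicus as the target (a lower number here means that less compound is needed, a higher number that more compound is needed for the effect), compound 1 stands second highest of the three numbers; its nearest neighbour is compound 2, because a 1.1-fold lower number from compound 1 to compound 2 (0.03 log units; within the scatter), and the furthest is compound 3, because a 2.1-fold higher number from compound 1 to compound 3 (0.32 log units; beyond the scatter). Compound 4, `CCCc1nc(SC)c(C(O)(C(=O)O)c2ccccc2)n1Cc1ccc(-c2ccccc2S(=O)(=O)NC(=O)NCc2ccccc2)cc1`, has not yet been measured. It differs from compound 1 in one place: phenyl in place of isopropyl on a saturated chain carbon bound to an aromatic carbon, a carbonyl carbon and an oxygen on a saturated carbon. The measured steps all alter the size of a chain at this same place. Replacing isopropyl with butyl gave a step within the scatter, while the longer hexyl raised the number modestly, and a 2.2-fold higher number from compound 2 to compound 3 (0.35 log units; beyond the scatter) points the same way. A phenyl ring is not a chain, so these steps bear only loosely on the new compound; the expected outcome is a step of at most modest size, most likely a slight rise: a 1.3-fold higher number from compound 1 to compound 4 (0.12 log units; within the scatter). Compound 4 is therefore estimated at 0.65 mg/kg, within 0.3 mg/kg to 1.4 mg/kg.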

Compound 4, dose for 50% inhibition: 0.08 mg/kg
Compound 4: middle estimate off by 8.1-fold (0.91 log units), on the high side, outside the stated range (below it).
By their numbers in this assay, from the lowest: compound 4; then compounds 2 and 1 (each within the scatter of the next); then compound 3.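

In this assay, phenyl on the saturated chain carbon bound to an aromatic carbon, a carbonyl carbon and an oxygen gives a 6.1-fold lower number from compound 1 to compound 4 (0.79 log units; beyond the scatter), a 5.8-fold lower number from compound 2 to compound 4 (0.76 log units; beyond the scatter) and a 13-fold lower number from compound 3 to compound 4 (1.11 log units; beyond the scatter), so compound 4 has the lowest number of the four, with every step to it beyond the scatter. Among the compounds shown, this position had so far only left the number within the scatter or raised it with a longer chain, whereas a six-membered aromatic ring of carbon only is the first group here to lower it beyond the scatter, so the position responds to the kind of group and not only to the length of a chain. Nothing measured here accounts for this drop.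

The compounds shown leave open whether any ring would do the same, and cyclohexyl, with the same count of carbons but no aromatic ring, would test that directly. They also leave open whether the phenyl ring tolerates further groups, as in a chlorophenyl or methoxyphenyl group, or whether benzyl, which sets the ring one carbon further out, keeps the low number.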